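Cytotoxicity notes on side-chain variants of a shared core

A few compounds are considered here, and "the series" means these few. Any claim that something is new, unique, unknown or untested is made for them only; others in the source may bear on it.

Compound 1 `Cc1nc(NCC(C)C)nc(N[C@@H]2C[C@H](CO)[C@@H](O)[C@H]2O)c1-c1nc2ccccc2s1` gives 10000 nM in an ADME assay on cells (Homo sapiens) for cytotoxicity, read by polymerase chain reaction, with a stated time of 3 days; on this read-out higher numbers stand for lower toxicity in this test and lower numbers for higher toxicity in this test.
Compound 3 `Cc1nc(NCCC(F)(F)F)nc(N[C@@H]2C[C@H](CO)[C@@H](O)[C@H]2O)c1-c1nc2ccccc2s1` gives 9000 nM in this assay.
Compound 2 `Cc1nc(NCCNC(=O)NC(C)(C)C)nc(N[C@@H]2C[C@H](CO)[C@@H](O)[C@H]2O)c1-c1nc2ccccc2s1` returns only a limit in this assay, > 25000 nM, and not a number.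

Among the numbers given, compound 3 stands lowest of two, with compound 1 nearest: the change from compound 1 to compound 3 reads a 1.1-fold lower number from compound 1 to compound 3 (0.05 log units; within the scatter), so the two are not separable. The third value is a limit (the limit of > 25000 nM in this assay, at which 1 of the 3 values shown sits).

Compound 4 `Cc1nc(NCc2ccncc2)nc(N[C@@H]2C[C@H](CO)[C@@H](O)[C@H]2O)c1-c1nc2ccccc2s1` is not yet measured. It differs from compound 3 in one place: pyridin-4-yl in place of 2,2,2-trifluoroethyl on a saturated chain carbon bound to a nitrogen on an aromatic ring. Two measured steps at the same saturated chain carbon bear on this. Exchanging isopropyl for 2,2,2-trifluoroethyl left the number essentially unchanged, while the step from compound 2 to compound 3 was an at least 2.7-fold lower number from compound 2 to compound 3 (0.44 log units; beyond the scatter), the urea-bearing chain sitting at the limit. The entering pyridin-4-yl brings one hydrogen-bond acceptor where the 2,2,2-trifluoroethyl had none, so the step is expected to lie between these two cases, probably upward and at most modest, with a real chance of another limit.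

Compound 4 is therefore estimated at 15000 nM, range 6000 nM to 30000 nM, meaning an expected step of a 1.7-fold higher number from compound 3 to compound 4 (0.22 log units; within the scatter).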

Compound 4, half-maximal cytotoxic concentration: 7000 nM
Beside the measured number, compound 4's estimate is 2.1-fold (0.33 log units) above it, and the stated range covers the measured number.
By their numbers in this assay, from the lowest: compounds 4, 3 and 1 (each within the scatter of the next). At a limit, above all of these: compound 2.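

Working notes on this position: in this assay, pyridin-4-yl is the first ring-bearing group at the saturated chain carbon bound to a nitrogen on an aromatic ring, and the reading stays within the scatter of both earlier small groups, with a 1.3-fold lower number from compound 3 to compound 4 (0.11 log units; within the scatter) and a 1.4-fold lower number from compound 1 to compound 4 (0.15 log units; within the scatter). Compounds 1, 3 and 4 therefore cannot be separated here, so neither the aromatic ring nor the single hydrogen-bond acceptor of pyridin-4-yl produces a measurable change against isopropyl or 2,2,2-trifluoroethyl, whereas (((tert-butyl)carbamoyl)amino)methyl still stands apart, with an at least 3.5-fold lower number from compound 2 to compound 4 (0.55 log units; beyond the scatter). Compound 2 remains the one exception to this grouping, and its value is a limit and not a number: the limit of > 25000 nM in this assay, at which 1 of the 4 values shown sits.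

Still open, as far as these compounds go, is whether a longer chain ending in a carboxylic acid or a primary amine at this carbon would read with compounds 1, 3 and 4 or would stand apart with compound 2. Also open, from the compounds shown here alone, is whether a pyridin-2-yl or a plain phenyl group would read with compound 4, and how large the true gap to compound 2 is.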